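The source may report more compounds than this note shows. Statements on the series, on what has been measured and on what is new or still open speak of the compounds shown alone.

Measured compounds:
compound 1, `COc1ccc(N(C)c2nc(C)nc3ccccc23)cc1C(=O)OCC[Se]C#N`, in a functional assay on HepG2 cells (Homo sapiens) for inhibition, read by MTT assay, with a stated time of 48 h (a lower number here means a stronger inhibitor, a higher number a weaker inhibitor), gives 890 nM;
compound 2, `Cc1nc(N(C)c2ccc([Se]C#N)c(Cl)c2)c2ccccc2n1`, in this assay gives 12 nM.

Of the two numbers, compound 1 stands highest, and its gap to compound 2 lies beyond the scatter. Compound 3, `COc1ccc(N(C)c2nc(C)nc3ccccc23)cc1OCCCCC[Se]C#N`, is not yet measured. It differs from compound 1 in one place: a group of 9 heavy atoms (6 carbon, 1 nitrogen, 1 oxygen, 1 selenium; no ring) in place of a group of 8 heavy atoms (4 carbon, 1 nitrogen, 2 oxygen, 1 selenium; no ring), on an aromatic carbon. Among the compounds with values here, no measured pair shows such a change, so the account can only guess its size; a step of modest size, within or just beyond the scatter and leaning toward a lower number, is expected. Compound 3 is therefore estimated at 600 nM, in the range 150 nM to 2500 nM, a step of a 1.5-fold lower number from compound 1 to compound 3 (0.17 log units; within the scatter) expected from the change.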

Compound 3, half-maximal inhibitory concentration: 5210 nM
The estimate for compound 3 lay 8.7-fold (0.94 log units) below the measured number; measured number above the stated range.
By their numbers in this assay, from the lowest: compound 2; then compound 1; then compound 3.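

On the aromatic carbon ortho to a methoxy group, the side chain carrying the selenium matters: in this assay, replacing the group of 8 heavy atoms with the group of 9 heavy atoms, which has no double bond outside aromatic rings, gives a 5.9-fold higher number from compound 1 to compound 3 (0.77 log units; beyond the scatter) and so a clear loss of inhibition. The earlier compounds shown here could not show that this place responds to the make-up of the chain. Nothing measured here explains the step. The compounds shown leave open whether the carbonyl or the chain length drives it, and how an amide link or a shorter chain would fare here.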